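The source may hold more compounds than are shown below. What is called first, only, known or untested is meant among the compounds shown, and "the series" means these compounds.

Compounds measured so far in an ADME assay on microsomes from liver (Homo sapiens) for metabolic stability; on this read-out lower numbers stand for slow clearance and higher numbers for fast clearance
compound 1 `Cc1cc2ncccc2cc1Nc1ncc2c(n1)n(C1CCOCC1)c(=O)n2C` gives 30 mL.min-1.g-1
compound 2 `Cc1cc2ncncc2cc1Nc1ncc2c(n1)n(C1CCOCC1)c(=O)n2C` gives > 200 mL.min-1.g-1 as a limit
compound 3 `Cc1cc2ncccc2cc1Nc1ncc2c(n1)n(C1CCN(C)CC1)c(=O)n2C` gives < 4 mL.min-1.g-1 as a limit

Compound 3 stands at the limit of < 4 mL.min-1.g-1 in this assay, at which 1 of the 3 values shown sits, and so carries a limit, not a number. Compound 4 `Cc1cc2ncccc2cc1Nc1ncc2c(n1)n(C1CCNCC1)c(=O)n2C` differs from it by hydrogen in place of methyl on an amine nitrogen in a ring and reads as hydrogen in place of methyl on an amine nitrogen in a ring, 1-methylpiperidin-4-yl to piperidin-4-yl.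

For the measured compounds named here, one measured step bears on this part of the structure: an at least 7.5-fold lower number from compound 1 to compound 3 (0.87 log units; beyond the scatter) is what brought in the 1-methylpiperidin-4-yl group. That step replaces oxan-4-yl and gives no size for losing the methyl alone. Going by the values given here, no measured step covers that loss, so no step beyond the scatter is expected in this assay and any drift would more likely be upward from the limit. The estimated change is a number no lower from compound 3 to compound 4 (the limit leaves the size open) and should be read with that limit in mind. For compound 4 the estimated value is 4 mL.min-1.g-1 with 2 mL.min-1.g-1 to 10 mL.min-1.g-1 as the expected range.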

Compound 4, intrinsic clearance in microsomes: < 4 mL.min-1.g-1
Compound 4: only a limit was reported; the forecaster's own chance of this, stated with the estimate: 55%; the middle value lies on the limit itself.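

In this assay compound 4 gives < 4 mL.min-1.g-1, which is a limit and not a number. Piperidin-4-yl in place of oxan-4-yl on the aromatic nitrogen gives an at least 7.5-fold lower number from compound 1 to compound 4 (0.87 log units; beyond the scatter), so the drop in clearance seen with 1-methylpiperidin-4-yl does not require the methyl on the ring nitrogen. The size of the change from methyl to hydrogen on the amine nitrogen in the ring cannot be read, because both compounds sit at one limit: the limit of < 4 mL.min-1.g-1 in this assay, at which 2 of the 4 values shown sit.

Where compound 3 and compound 4 truly lie relative to each other stays open. Also open, on these data alone, are whether an acetyl group on that ring nitrogen, or an open-chain amine in place of the ring, keeps the reading at this limit, and whether piperidin-4-yl does the same on the core of compound 2.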